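Cytotoxicity notes: hydrazone aryl swap in the shared core

The source may report more compounds than this note shows. Statements on the series, on what has been measured and on what is new or still open speak of the compounds shown alone.

Compound 1 `COc1ccccc1-c1nnc(-c2ccc(C(=O)N/N=C/c3ccccc3O)cc2)o1` sits at the highest of the two numbers in an ADME assay on THP-1 cells (Homo sapiens) for cytotoxicity (a higher number here means a weaker inhibitor, a lower number a stronger inhibitor), where compound 1 gives 207000 nM. Compound 2 `COc1ccccc1-c1nnc(-c2ccc(C(=O)N/N=C/c3ccc(O)cc3O)cc2)o1` gives 104000 nM in this assay; the step of a 2.0-fold lower number from compound 1 to compound 2 (0.30 log units; within the scatter) stays within the scatter. Compound 3 `COc1ccccc1-c1nnc(-c2ccc(C(=O)N/N=C/c3ccccn3)cc2)o1` differs from compound 1 by pyridin-2-yl in place of 2-hydroxyphenyl on a carbon with a double bond to nitrogen. Among the compounds with values here, no measured step involves this exchange, and the only measured step is a different change. For compound 3 a step of a 1.0-fold lower number from compound 1 to compound 3 (0.01 log units; within the scatter) within the scatter is therefore expected. The value expected for compound 3 in this assay is 200000 nM, with a range from 70000 nM to 500000 nM.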

Compound 3, half-maximal inhibitory concentration: 67000 nM
The estimate for compound 3 lay 3.0-fold (0.47 log units) above the measured number; the measured number lies below the stated range.
By their numbers in this assay, from the lowest: compounds 3, 2 and 1 (each within the scatter of the next, the first and the last beyond it).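

Within the data shown here, at the carbon with a double bond to nitrogen, pyridin-2-yl in place of 2-hydroxyphenyl gives, in this assay, a 3.1-fold lower number from compound 1 to compound 3 (0.49 log units; beyond the scatter), the only step beyond the scatter. Pyridin-2-yl in place of 2,4-dihydroxyphenyl gives a 1.6-fold lower number from compound 2 to compound 3 (0.19 log units; within the scatter), so compound 3 is not separated from compound 2. No evidence on the origin of the step is available.

Open, going by these compounds, is whether the step follows the loss of the hydroxy group or the entry of the ring nitrogen; an unsubstituted phenyl would separate the two. Also open, on these data alone, is how an amine or a carboxylic acid on this aromatic ring would read.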